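A few compounds are considered here, and "the series" means these few. Any claim that something is new, unique, unknown or untested is made for them only; others in the source may bear on it.

Compound 3 `CCc1nc(C(=O)N(C)C)c2n1CCN([C@@H](C(=O)NC)c1ccccc1)C2CCc1ccc(C(F)(F)F)cc1` gives 344 nM in a functional assay on CHO cells for antagonist activity at Orexin/Hypocretin receptor type 1 (Homo sapiens), read by FLIPR and calcium flux (a higher number here means a weaker inhibitor, a lower number a stronger inhibitor), the second highest of the three numbers recorded. Its nearest neighbour is compound 2 `C=Cc1nc(CC)n2c1C(CCc1ccc(C(F)(F)F)cc1)N([C@@H](C(=O)NC)c1ccccc1)CC2`, which gives 150 nM; the furthest is compound 1 `CCc1nc(C(C)C)c2n1CCN([C@@H](C(=O)NC)c1ccccc1)C2CCc1ccc(C(F)(F)F)cc1`, which gives 10000 nM. Compound 4 `CCc1ncc2n1CCN([C@@H](C(=O)NC)c1ccccc1)C2CCc1ccc(C(F)(F)F)cc1` has not yet been measured and differs from compound 3 in one place: hydrogen in place of dimethylcarbamoyl on an aromatic carbon.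

Three measured steps all turn on the same aromatic carbon and therefore bear on this change. There was a 67-fold lower number from compound 1 to compound 2 (1.82 log units; beyond the scatter) and a 29-fold lower number from compound 1 to compound 3 (1.46 log units; beyond the scatter), both large, while the move between the two smaller groups was modest, a 2.3-fold higher number from compound 2 to compound 3 (0.36 log units; beyond the scatter). Removing the dimethylcarbamoyl altogether to leave a hydrogen has no direct precedent among these compounds, but the measured steps show that the isopropyl carries a heavy penalty and that the two other groups sit within a modest span of each other. Compound 4 is therefore expected to land close to compound 3, with the step of a 1.4-fold lower number from compound 3 to compound 4 (0.14 log units; within the scatter) estimated as at most modest in either direction, and its value in this assay is estimated at 250 nM, in the range 60 nM to 1000 nM.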

Compound 4, half-maximal inhibitory concentration: 10000 nM
Compound 4: middle estimate off by 40-fold (1.60 log units), on the low side, outside the stated range (above it).
By their numbers in this assay, from the lowest: compound 2; then compound 3; then compounds 1 and 4 (each within the scatter of the next).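

In this assay the hydrogen compound is no neutral baseline for this aromatic carbon: a 29-fold higher number from compound 3 to compound 4 (1.46 log units; beyond the scatter) and a 67-fold higher number from compound 2 to compound 4 (1.82 log units; beyond the scatter) show that dimethylcarbamoyl and vinyl each go with a much lower number than hydrogen. Isopropyl, which looked like a heavy penalty in the earlier compounds, cannot be told apart from hydrogen here, with no change at the digits printed from compound 1 to compound 4 (within the scatter) standing between the two. The large earlier steps from compound 1 therefore read as gains tied to vinyl and dimethylcarbamoyl, rather than as a loss peculiar to isopropyl.

On these data alone, whether an ethyl, a nitrile, a methyl ester or a primary carboxamide on this carbon would also give a lower number than hydrogen remains open. No measurement among these compounds accounts for the split between these groups.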